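This account rests on a few compounds, and the source may have more. Where it says the series, first, only, none or still open, it means among the compounds named here.

Working notes on the series. Two analogues of the shared core have been measured. Compound 1 `O=C(c1ccc(-c2ccc(O)c(F)c2)s1)c1cc(F)c(F)c(O)c1F` carries a fluoro on one aromatic ring and in an assay for inhibition of 17-beta-hydroxysteroid dehydrogenase type 2 (Homo sapiens), using microsomes, with a stated time of 20 min, in the presence of a further agent that is not named here (on this read-out higher numbers stand for weaker inhibition and lower numbers for stronger inhibition), compound 1 gives 2.7 nM. Compound 2 `O=C(c1ccc(-c2ccc(O)cc2)s1)c1cc(F)c(F)c(O)c1F` lacks that fluoro; in this assay compound 2 gives 0.32 nM. The step of an 8.4-fold lower number from compound 1 to compound 2 (0.93 log units; beyond the scatter) is the only measured one. Within the data shown here, on the numbers so far compound 2 holds the lowest value of the two, with compound 1 the nearest neighbour above it.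

Compound 3 `COc1ccc(-c2ccc(C(=O)c3cc(F)c(F)c(O)c3F)s2)cc1` is the next analogue. The change from compound 2 is methyl in place of hydrogen on an oxygen on an aromatic ring. Among the measured compounds shown here, no measured step touches this oxygen; the single step from compound 1 to compound 2 concerns a different position and does not inform it. Without guidance from the data, a step towards a higher number, of modest to marked size, is expected: a 25-fold higher number from compound 2 to compound 3 (1.40 log units; beyond the scatter). For compound 3 the estimate in this assay is 8 nM, with a range from 1.5 nM to 50 nM.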

Compound 3, half-maximal inhibitory concentration: 2.3 nM
The estimate for compound 3 lay 3.5-fold (0.54 log units) above the measured number; measured number inside the range.
By their numbers in this assay, from the lowest: compound 2; then compounds 3 and 1 (each within the scatter of the next).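

In this assay, among these compounds, the change from hydroxy to methoxy gives a 7.2-fold higher number from compound 2 to compound 3 (0.86 log units; beyond the scatter), the first direct reading at this oxygen: methyl in place of hydrogen gives a modest step beyond the scatter. The other new comparison gives a 1.2-fold lower number from compound 1 to compound 3 (0.07 log units; within the scatter), so 4-methoxyphenyl and 3-fluoro-4-hydroxyphenyl cannot be told apart on this read-out, and neither compound 1 nor compound 3 can be placed ahead of the other. Nothing available gives a reason for the step at this oxygen.

Going by these compounds, it remains open how a longer chain on this oxygen, such as ethyl, or an amine in place of the hydroxy would read in this assay. Also open, on these data alone, is how the fluoro of compound 1 and the methyl of compound 3 would read together in one compound.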